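Replacing the Naphthyl Group on the Shared Core

This account rests on a few compounds, and the source may have more. Where it says the series, first, only, none or still open, it means among the compounds named here.

Three compounds built on a shared core were tested in a functional assay on Ehrlich cells (Mus musculus) for cytotoxicity, tested at 10 ug/mL; a higher number here means a stronger effect of the compound at the concentration tested, a lower number a weaker effect. Compound 1 `COc1cc(N2C(N)=C(C#N)C(c3ccc([N+](=O)[O-])cc3)C3=C2CC(C)(C)CC3=O)cc(OC)c1OC` gives 10%, compound 2 `COc1cc(N2C(N)=C(C#N)C(c3ccc(OC)c4ccccc34)C3=C2CC(C)(C)CC3=O)cc(OC)c1OC` gives 10%, and compound 3 `COc1cc(N2C(N)=C(C#N)C(c3c(O)ccc4ccccc34)C3=C2CC(C)(C)CC3=O)cc(OC)c1OC` gives 2%. Compound 3 has the smallest of the three numbers, but the steps of a number 8 percentage points lower from compound 1 to compound 3 (within the scatter) and a number 8 percentage points lower from compound 2 to compound 3 (within the scatter) both lie within the scatter, so the three compounds are not truly separated on this read-out. Compound 4 `COc1cc(N2C(N)=C(C#N)C(c3ccc(C)cc3)C3=C2CC(C)(C)CC3=O)cc(OC)c1OC` differs from compound 3 in one place: 4-methylphenyl in place of 2-hydroxynaphthalen-1-yl on a saturated ring carbon. Within the data shown here, the steps that bear on this change are the earlier exchanges of the group on the same saturated ring carbon, namely no change at the digits printed from compound 1 to compound 2 (within the scatter), a number 8 percentage points lower from compound 1 to compound 3 (within the scatter) and a number 8 percentage points lower from compound 2 to compound 3 (within the scatter), none of which moved the read-out beyond the scatter. Compound 4 is therefore expected to show a step of a number 5 percentage points higher from compound 3 to compound 4 (within the scatter), which stays within the scatter, with no direction favoured. The estimate for compound 4 is 7%, with a range from 0% to 20%.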

Compound 4, a percentage reported as activity, at one concentration (the size of the read-out at that concentration, not a potency): 30%
The estimate for compound 4 lay 23 percentage points below the measured number, outside the stated range (above it).
By their numbers in this assay, from the lowest: compounds 3, 1 and 2 (each within the scatter of the next); then compound 4.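

Among these compounds, on the saturated ring carbon of the shared core, 4-methylphenyl is the first group to lift the number in this assay beyond the scatter, with a number 28 percentage points higher from compound 3 to compound 4 (beyond the scatter) and a number 20 percentage points higher from compound 2 to compound 4 (beyond the scatter) against the two naphthyl compounds. The exchange of nitro for methyl on the aromatic carbon, with a number 20 percentage points higher from compound 1 to compound 4 (beyond the scatter) as its step, shows that a single aromatic ring at this position is not enough on its own, as compound 1 also carries one yet stays within the scatter of compound 2 and compound 3. No measurement available here explains the rise.

Going by these compounds, whether the methyl itself matters stays open, as a plain phenyl or a 4-ethylphenyl at this carbon would separate its presence from the mere absence of nitro. Also open, on these data alone, is how an amine or a carboxylic acid on the same aromatic carbon would read.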